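A few compounds are considered here, and "the series" means these few. Any claim that something is new, unique, unknown or untested is made for them only; others in the source may bear on it.

In a functional assay on HL-60 cells (Homo sapiens) for antiproliferative activity, with a stated time of 24 h (a higher number here means a weaker inhibitor, a lower number a stronger inhibitor), three compounds have so far been measured. Compound 1, `NC(=O)c1c(NC(=O)c2ccc(C(F)(F)F)cc2)sc2c1CCN(Cc1ccc(Cl)cc1Cl)C2`, gives 14900 nM in this assay. Compound 2, `Cc1ccc(C(=O)Nc2sc3c(c2C(N)=O)CCN(Cc2ccc(Cl)cc2Cl)C3)cc1`, differs from compound 1 in a single place: methyl in place of trifluoromethyl on an aromatic carbon. In this assay compound 2 gives 19900 nM, so this change made a step of a 1.3-fold higher number from compound 1 to compound 2 (0.13 log units; within the scatter); the number hardly moved. Compound 3, `NC(=O)c1c(NC(=O)c2ccccc2Br)sc2c1CCN(C(=S)Nc1ccccc1C(F)(F)F)C2`, is built on a different core, and the difference between the two cores is not broken down here. In this assay compound 3 gives 27400 nM.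

Compound 4, `Cc1ccccc1NC(=S)N1CCc2c(sc(NC(=O)c3ccccc3Br)c2C(N)=O)C1`, has not yet been measured. It differs from compound 3 in one place: methyl in place of trifluoromethyl on an aromatic carbon. Among the compounds with values here, this is the same kind of change as the one from compound 1 to compound 2, but the surroundings differ: in the first pair the group sits para to a large group, in the second pair it sits ortho to a large group. Within the data shown here, the only guide available is the earlier step, which stayed within the scatter, and the new pair carries a different core. The expected step of a 1.1-fold higher number from compound 3 to compound 4 (0.04 log units; within the scatter) therefore rests on the step of a 1.3-fold higher number from compound 1 to compound 2 (0.13 log units; within the scatter) and is estimated to be small as well, with a wide margin for the changed surroundings. Compound 4 is expected to give about 30000 nM in this assay, most likely between 14000 nM and 65000 nM.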

Compound 4, half-maximal inhibitory concentration: > 50000 nM
Compound 4 ended at the assay's limit; the forecaster's own chance of this, stated with the estimate: 20%; at least 1.6-fold (0.22 log units) between middle value and limit.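

In this assay compound 4 gives > 50000 nM, which is a limit of the assay and not a number: the limit of > 50000 nM in this assay, at which 1 of the 4 values shown sits. Replacing trifluoromethyl with methyl therefore gives a step of an at least 1.8-fold higher number from compound 3 to compound 4 (0.26 log units; that floor lies within the scatter), a figure that marks only the lower end of what the true step could be. This pair and the earlier one show the same swap on two different cores without a rise beyond the scatter being established in either, but they do not show that the change carries over from one core to the other with the same size, nor that its size depends on the core: the same change on two cores in this assay, a 1.3-fold higher number (0.13 log units; within the scatter) from compound 1 to compound 2 and an at least 1.8-fold higher number (0.26 log units; that floor lies within the scatter) from compound 3 to compound 4; the limit leaves it open whether they differ.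

A firm value for compound 4 would be needed to settle whether the step on the core of compound 3 is the larger one, and two pairs are too few to support a rule for the series. The compounds shown also leave open what a methoxy group, an amine or a carboxylic acid would do in place of the methyl or the trifluoromethyl on either core.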